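Methyl in place of cyano on the aryl ring

The source may hold more compounds than are shown below. What is called first, only, known or untested is meant among the compounds shown, and "the series" means these compounds.

Compound 3 `Cn1nnnc1SCC(=O)N/N=c1/scc(-c2ccc(C#N)cc2)n1-c1ccccc1` gives the lowest of the two numbers in a functional assay on C6 cells (Rattus norvegicus) for cytotoxicity, read by MTT assay, with a stated time of 24 h (a higher number here means a weaker inhibitor, a lower number a stronger inhibitor), 23.3 ug/mL. Compound 1 `Cc1ccc(-c2cs/c(=N/NC(=O)CSc3ncccn3)n2-c2ccccc2)cc1` gives 85 ug/mL in this assay. In this assay compound 2 `Cn1nnnc1SCC(=O)N/N=c1/scc(-c2ccc([N+](=O)[O-])cc2)n1-c1ccccc1` reaches only a limit, > 200 ug/mL. Within the data shown here, the single measured step, an at least 8.5-fold lower number from compound 2 to compound 3 (0.93 log units; beyond the scatter), is the only change at this aromatic carbon for which numbers exist. Compound 4 `Cc1ccc(-c2cs/c(=N/NC(=O)CSc3nnnn3C)n2-c2ccccc2)cc1` differs from compound 3 by methyl in place of cyano on an aromatic carbon. Among the measured compounds shown here, no measured step exchanges cyano for methyl; compound 1 carries the same 4-methylphenyl group, but it also differs from compound 4 elsewhere, so its value is at best a loose guide. A modestly higher number is therefore expected for compound 4, a step of a 2.6-fold higher number from compound 3 to compound 4 (0.41 log units; beyond the scatter). Compound 4 is estimated at 60 ug/mL in this assay, within 25 ug/mL to 150 ug/mL.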

Compound 4, half-maximal inhibitory concentration: 36.3 ug/mL
Compound 4: the middle estimate sits 1.7-fold (0.22 log units) above what was measured, within the range that was stated.
By their numbers in this assay, from the lowest: compounds 3 and 4 (each within the scatter of the next); then compound 1. At a limit, above all of these: compound 2.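

A step of a 1.6-fold higher number from compound 3 to compound 4 (0.19 log units; within the scatter) in this assay does not separate methyl from cyano on this aromatic carbon. Nitro alone stands apart among the three groups, with an at least 5.5-fold lower number from compound 2 to compound 4 (0.74 log units; beyond the scatter) read against a limit for compound 2. The group on sulfur also matters, with a 2.3-fold lower number from compound 1 to compound 4 (0.37 log units; beyond the scatter) for 1-methyl-1H-tetrazol-5-yl in place of pyrimidin-2-yl while the 4-methylphenyl group stays.

From the compounds shown here alone, whether an amine or a carboxylic acid on this carbon would group with cyano and methyl or with nitro remains open. So does whether the step on sulfur holds with the 4-cyanophenyl group.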